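Oxan-4-yl in place of hydroxymethyl on compound 1

The source may hold more compounds than are shown below. What is called first, only, known or untested is meant among the compounds shown, and "the series" means these compounds.

Among the compounds with values here, compound 1 `NC(=O)c1cc(Cl)c2c(Cl)c(C#CCO)n([C@H]3CCCNC3)c2n1` gives 301 nM in a functional assay on KG-1 cells (Homo sapiens) for antiproliferative activity (a lower number here means that less compound is needed, a higher number that more compound is needed for the effect), the highest of the three numbers measured so far: compound 3 `CC(O)C#Cc1c(Cl)c2c(Cl)cc(C(N)=O)nc2n1[C@H]1CCCNC1` gives 147 nM and compound 2 `CC(O)CC#Cc1c(Cl)c2c(Cl)cc(C(N)=O)nc2n1[C@H]1CCCNC1` gives 48 nM. Compound 4 `NC(=O)c1cc(Cl)c2c(Cl)c(C#CC3CCOCC3)n([C@H]3CCCNC3)c2n1` differs from compound 1 by oxan-4-yl in place of hydroxymethyl on a triple-bonded carbon. Within the data shown here, the steps that bear on this change are a 2.0-fold lower number from compound 1 to compound 3 (0.31 log units; beyond the scatter) and a 6.3-fold lower number from compound 1 to compound 2 (0.80 log units; beyond the scatter), both modest and both lowering the number, while a 3.1-fold higher number from compound 2 to compound 3 (0.49 log units; beyond the scatter). Both earlier changes on the triple-bonded carbon lowered the number, so a modest lowering is expected for compound 4, namely a 3.0-fold lower number from compound 1 to compound 4 (0.48 log units; beyond the scatter), although oxan-4-yl goes beyond what has been tested. Compound 4 is therefore estimated at 100 nM, with a range from 30 nM to 350 nM.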

Compound 4, half-maximal effective concentration: 69 nM
For compound 4 the middle estimate is 1.4-fold (0.16 log units) above the measured one; low and high end bracket the measured number.
By their numbers in this assay, from the lowest: compounds 2 and 4 (each within the scatter of the next); then compound 3; then compound 1.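

In this assay the oxan-4-yl group, which has no hydrogen-bond donor, gives a 4.4-fold lower number from compound 1 to compound 4 (0.64 log units; beyond the scatter) and a 2.1-fold lower number from compound 3 to compound 4 (0.33 log units; beyond the scatter) on the triple-bonded carbon, so a donor in this group is not required for a lower number among these compounds. Against the 2-hydroxypropyl group there is a 1.4-fold higher number from compound 2 to compound 4 (0.16 log units; within the scatter) and the two groups cannot be told apart here. No other measurement bears on these steps. As far as these compounds go, it remains open how an amine, a carboxylic acid or a ring of another size on this carbon would compare with oxan-4-yl.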